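Cyclohexyl in Place of Pyridin-4-yl at the Ring Amine

The compounds below may be only part of what the source reports. "The series", "measured", "known", "first", "only" and "open" are said of these compounds alone.

Within the data shown here, compound 1 `O=C(CN1CCN(c2ccncc2)CC1)Nc1nc2c(s1)CCCC2` is one of two compounds measured in an assay on isolated protein for inhibition of long-chain fatty acid transport protein 1 (Mus musculus), read by scintillation counting, with a stated time of 20 min; on this read-out higher numbers stand for weaker inhibition and lower numbers for stronger inhibition. For compound 1 this assay reports only a limit, > 10000 nM, and not a number. The other measured compound, compound 2 `CC1CCc2sc(NC(=O)CN3CCN(c4ccc(F)cc4)CC3)nc2C1`, gives 5100 nM in this assay. Compound 1 thus sits at the limit (the limit of > 10000 nM in this assay, at which 1 of the 2 values shown sits). Compound 3 `O=C(CN1CCN(C2CCCCC2)CC1)Nc1nc2c(s1)CCCC2` differs from compound 1 by cyclohexyl in place of pyridin-4-yl on an amine nitrogen in a ring. Among the measured compounds shown here, no step between measured compounds has been recorded. The step of an at least 2.0-fold lower number from compound 1 to compound 3 (0.30 log units; that floor lies within the scatter) is expected to run toward stronger inhibition, though it may not pass beyond the scatter. Compound 3 is expected to give 5000 nM, within 1500 nM to 30000 nM.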

Compound 3, half-maximal inhibitory concentration: > 10000 nM
Compound 3: only a limit was reported; the forecaster's own chance of this, stated with the estimate: 40%; middle value at least 2.0-fold (0.30 log units) away from the limit.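

Compound 1 and compound 3 both report only a limit, so no step can be read between them: the limit of > 10000 nM in this assay, at which 2 of the 3 values shown sit.

From the compounds shown here alone, whether cyclohexyl or pyridin-4-yl on the ring amine gives stronger inhibition in this assay stays open.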